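Changing the Aryl Group on the Aromatic Nitrogen

The source may hold more compounds than are shown below. What is called first, only, known or untested is meant among the compounds shown, and "the series" means these compounds.

Compound 2 `N#CC1=C(N)Oc2c(c3nc4ccccc4nc3c3ccccc23)C12C(=O)N(Cc1cnnn1-c1cccc(Cl)c1)c1ccccc12` was measured in a functional assay on A549 cells (Homo sapiens) for antiproliferative activity, read by MTT assay, with a stated time of 48 h (on this read-out higher numbers stand for weaker inhibition and lower numbers for stronger inhibition), where compound 2 gives 32600 nM. Among the two numbers reported, that of compound 2 is the lowest, and its nearest neighbour is compound 1 `N#CC1=C(N)Oc2c(c3nc4ccccc4nc3c3ccccc23)C12C(=O)N(Cc1cnnn1-c1ccccc1Cl)c1ccccc12`, which in this assay gives 42600 nM; the step of a 1.3-fold lower number from compound 1 to compound 2 (0.12 log units; within the scatter) lies within the scatter. Compound 3 `CCOc1ccccc1-n1nncc1CN1C(=O)C2(C(C#N)=C(N)Oc3c2c2nc4ccccc4nc2c2ccccc32)c2ccccc21` reaches only a limit of this assay, > 50000 nM. The step of an at least 1.1-fold higher number from compound 1 to compound 3 (0.06 log units; that floor lies within the scatter) and the step of an at least 1.5-fold higher number from compound 2 to compound 3 (0.18 log units; that floor lies within the scatter) also stay within the scatter, as noted for the limit (the limit of > 50000 nM in this assay, at which 1 of the 3 values shown sits).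

Compound 4 `Cc1ccc(-n2nncc2CN2C(=O)C3(C(C#N)=C(N)Oc4c3c3nc5ccccc5nc3c3ccccc43)c3ccccc32)c(C)c1` differs from compound 2 by the change (2,4-dimethylphenyl in place of 3-chlorophenyl on an aromatic nitrogen). All three measured steps concern the same aryl group on the aromatic nitrogen, and none of them moved the number beyond the scatter. The step of a 1.2-fold higher number from compound 2 to compound 4 (0.09 log units; within the scatter) is therefore expected to be small, in no fixed direction. For compound 4 the estimated value in this assay is 40000 nM, with a range from 18000 nM to 90000 nM.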

Compound 4, half-maximal inhibitory concentration: > 50000 nM
Compound 4 gave a limit, no number (the forecaster's own chance of this, stated with the estimate: 35%); middle value at least 1.2-fold (0.09 log units) away from the limit.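

In this assay compound 4 stands at a limit of the assay and gives no number, so a second aryl group without chlorine joins compound 3 there: the limit of > 50000 nM in this assay, at which 2 of the 4 values shown sit.

Placing 2,4-dimethylphenyl on the aromatic nitrogen gives an at least 1.5-fold higher number from compound 2 to compound 4 (0.18 log units; that floor lies within the scatter) and an at least 1.1-fold higher number from compound 1 to compound 4 (0.06 log units; that floor lies within the scatter), so this change, like the earlier ones, shows no step beyond the scatter. Among the four compounds, only the two chlorophenyl compounds, 1 and 2, give numbers, and the step between the two limits cannot be read.

As far as these compounds go, it remains open whether any group at this position can move the number clearly beyond the scatter. A phenyl ring carrying an amine or a carboxylic acid, or a pyridine ring in place of the phenyl, might answer that.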